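Swapping a Fluorinated Sulfur Group for Pentafluoroethyl

The source may hold more compounds than are shown below. What is called first, only, known or untested is meant among the compounds shown, and "the series" means these compounds.

Of the compounds shown here, three have so far been measured in a functional assay on LNCaP cells (Homo sapiens) for antiproliferative activity, read by propidium iodide staining, with a stated time of 96 h; a higher number here means a weaker inhibitor, a lower number a stronger inhibitor. Compound 1, `CC(O)(CSc1cc(C(F)(F)F)cc(C(F)(F)F)c1)C(=O)Nc1cccc(S(F)(F)(F)(F)F)c1`, gives 4800 nM in this assay. Compound 2, `CC(O)(COc1cccc(S(F)(F)(F)(F)F)c1)C(=O)Nc1cc(C(F)(F)F)cc(C(F)(F)F)c1`, gives 3000 nM, and compound 3, `CC(O)(COc1cccc(C(F)(F)C(F)(F)F)c1)C(=O)Nc1cc(C(F)(F)F)cc(C(F)(F)F)c1`, gives 4400 nM. The three numbers lie close to one another, and none of the gaps among them reaches beyond the usual scatter of repeated measurements of this kind.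

Compound 3 differs from compound 2 in a single place: a group of 7 heavy atoms (2 carbon, 5 fluorine; no ring) in place of a group of 6 heavy atoms (5 fluorine, 1 sulfur; no ring), on an aromatic carbon. That change produced a 1.5-fold higher number from compound 2 to compound 3 (0.17 log units; within the scatter), so within this pair the swap left the antiproliferative activity essentially unchanged.

Compound 4, `CC(O)(CSc1cc(C(F)(F)F)cc(C(F)(F)F)c1)C(=O)Nc1cccc(C(F)(F)C(F)(F)F)c1`, has not yet been measured. It carries the same change relative to compound 1: a group of 7 heavy atoms (2 carbon, 5 fluorine; no ring) in place of a group of 6 heavy atoms (5 fluorine, 1 sulfur; no ring), on an aromatic carbon. The core of compound 1 is not the same as the core of compound 2, and the difference between the two cores is not broken down here.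

The expectation for compound 4 therefore rests on two things. The first is the measured step, a 1.5-fold higher number from compound 2 to compound 3 (0.17 log units; within the scatter), which shows the swap to be a small move. The second is the starting point, since compound 1 gives 4800 nM in this assay. The step expected here is a 1.4-fold higher number from compound 1 to compound 4 (0.13 log units; within the scatter), placed beside the measured step as a change of similar size. In this assay compound 4 is therefore expected to give about 6500 nM, most likely falling between 3000 nM and 14000 nM.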

Compound 4, half-maximal inhibitory concentration: 3900 nM
For compound 4 the middle estimate is 1.7-fold (0.22 log units) above the measured one; the measured number falls inside the stated range.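

In this assay, placing 1,1,2,2,2-pentafluoroethyl where the sulfur group with its five fluorines stood gives a 1.2-fold lower number from compound 1 to compound 4 (0.09 log units; within the scatter), a step that stays within the usual scatter. Set beside the earlier pair, the new step shows the same swap behaving alike on the two cores, with no difference that can be told apart from measurement noise: the same change on two cores in this assay, a 1.5-fold higher number (0.17 log units; within the scatter) from compound 2 to compound 3 and a 1.2-fold lower number (0.09 log units; within the scatter) from compound 1 to compound 4, 1.8-fold (0.26 log units) apart, within the scatter of two such steps. Among these compounds, for these two cores, then, 1,1,2,2,2-pentafluoroethyl can take the place of the sulfur group with no clear change in this assay, but this rests on only two pairs and does not show that the swap would behave the same way on any other core or in any other test.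

The compounds shown leave open what a different group at this place on the ring would do, such as a nitrile, an amine or a longer fluorinated carbon chain. They also leave open what the difference between the two cores contributes on its own, as compound 1 and compound 2 differ in more than one place and no single change between them can be read.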